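Methoxy scan on the selenoether series, cytotoxicity read-out

The source may hold more compounds than are shown below. What is called first, only, known or untested is meant among the compounds shown, and "the series" means these compounds.

Measured so far in a functional assay on SK-MEL-147 cells (Homo sapiens) for cytotoxicity, read by MTT assay, with a stated time of 24 h; on this read-out higher numbers stand for an effect only at larger amounts of compound and lower numbers for an effect already at smaller amounts:
- compound 1 `CCOC(=O)c1cc([Se]c2ccc3cc(OC)ccc3c2)c2cc(OC)ccc2n1` gives 30800 nM
- compound 2 `CCOC(=O)c1cc([Se]c2ccccc2)c2cc(OC)ccc2n1` gives 33000 nM
- compound 3 `CCOC(=O)c1cc([Se]c2ccc3ccccc3c2)c2cc(OC)ccc2n1` gives 32200 nM

The three numbers from this assay lie together; none of the gaps between them passes the scatter, so no ordering among compound 1, compound 2 and compound 3 is claimed. The change between compound 3 and compound 1 is methoxy in place of hydrogen on an aromatic carbon; the step it made in this assay is a 1.0-fold lower number from compound 3 to compound 1 (0.02 log units; within the scatter), within the scatter. The difference between the cores of compound 2 and compound 3 is not broken down here.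

Compound 4 `CCOC(=O)c1cc([Se]c2ccc(OC)cc2)c2cc(OC)ccc2n1` is not yet measured. It differs from compound 2 by methoxy in place of hydrogen on an aromatic carbon. Within the data shown here, this is the same kind of change as the one from compound 3 to compound 1, not the same one: in compound 1 the methoxy sits on a ring that is part of a fused or bridged system of two rings, meta to a fused ring and para to a fused ring, whereas in compound 4 it sits on a six-membered aromatic ring of carbon only, para to a large group.

For compound 4 the step expected in this assay is a 1.0-fold lower number from compound 2 to compound 4 (0.01 log units; within the scatter), which rests on compound 3 to compound 1 giving a 1.0-fold lower number from compound 3 to compound 1 (0.02 log units; within the scatter) and on all three measured numbers lying within the scatter of one another. The estimate for compound 4 in this assay is 32000 nM, expected to fall between 20000 nM and 50000 nM.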

Compound 4, half-maximal effective concentration: >= 54300 nM
Compound 4: a limit, no number; the forecaster's own chance of this, stated with the estimate: 5%; at least 1.6-fold (0.22 log units) between middle value and limit.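

Compound 4 has no number in this assay, only a limit of the assay: the limit of >= 54300 nM in this assay, at which 1 of the 4 values shown sits.

Read against compound 2, the swap of phenyl to 4-methoxyphenyl gives an at least 1.6-fold higher number from compound 2 to compound 4 (0.21 log units; that floor lies within the scatter), and since that figure is only a floor, the true size of the step remains unknown. This result therefore neither confirms nor rules out that methoxy in place of hydrogen on an aromatic carbon behaves alike on the two cores, and no general rule for carrying the change across this series can be drawn from one pair on each core. Set side by side, the two steps read: the same change on two cores in this assay, a 1.0-fold lower number (0.02 log units; within the scatter) from compound 3 to compound 1 and an at least 1.6-fold higher number (0.21 log units; that floor lies within the scatter) from compound 2 to compound 4; the limit leaves it open whether they differ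

The compounds shown leave open what an amine or a carboxylic acid would do in place of the methoxy at the same place, para to a large group, on the core of compound 2. They also leave open whether a longer chain in place of the methyl of the methoxy, or a change to the ester shared by all four compounds, would separate these compounds from one another in this assay.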